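Fluoro in Place of Hydrogen, Starting from a Limit

The source may report more compounds than this note shows. Statements on the series, on what has been measured and on what is new or still open speak of the compounds shown alone.

Going by the values given here, compound 2 `CC1(C)Cc2c(ccc(C(=O)/C=C/c3ccccc3)c2OCc2ccccc2)O1` and compound 1 `CC1(C)Cc2c(OCc3ccccc3)ccc(C(=O)/C=C/c3ccc(Cl)cc3Cl)c2O1` are the two measured members of this set. In a functional assay on PC-3 cells (Homo sapiens) for antiproliferative activity, read by MTT assay, with a stated time of 48 h (on this read-out higher numbers stand for weaker inhibition and lower numbers for stronger inhibition), compound 1 returns only a limit, > 100000 nM. In this assay compound 2 also returns only a limit, > 100000 nM. Both results sit at the limit of > 100000 nM in this assay, at which 2 of the 2 values shown sit, so compound 2 stands at the edge of what this assay reports, with no measured number beneath it. Compound 3 `CC1(C)Cc2c(ccc(C(=O)/C=C/c3ccc(F)cc3)c2OCc2ccccc2)O1` differs from compound 2 by fluoro in place of hydrogen on an aromatic carbon. Among the compounds with values here, with no measured step to guide this change, the step of a number no higher from compound 2 to compound 3 (the limit leaves the size open) is expected to be none beyond the usual scatter. Compound 3 is therefore estimated at 100000 nM, with a range from 30000 nM to 300000 nM, most probably reported as another limit.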

Compound 3, half-maximal inhibitory concentration: 44200 nM
Compound 3: the middle estimate sits 2.3-fold (0.35 log units) above what was measured; low and high end bracket the measured number.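

Fluoro in place of hydrogen on the aromatic carbon para to a large group gives the set its first number short of the limit in this assay, with an at least 2.2-fold lower number from compound 2 to compound 3 (0.35 log units; beyond the scatter). This position can therefore change the read-out, which compound 1 and compound 2 could not show. The full size of the step stays open, because compound 2 has only a limit: the limit of > 100000 nM in this assay, at which 2 of the 3 values shown sit.

From the compounds shown here alone, whether methoxy, an amine or a carboxylic acid at this position would lower the number further remains open. This single pair also leaves open whether fluoro would have the same effect at another position.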